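The compounds below may be only part of what the source reports. "The series", "measured", "known", "first", "only" and "open" are said of these compounds alone.

Notes on the series. Compound 1 `CCC1(Cc2ccccc2)OS(=O)(=O)C=C1OCC(=O)OC` carries a methoxycarbonyl on a saturated chain carbon bound to an oxygen on an unsaturated carbon. In an ADME assay on HEL cells (Homo sapiens) for cytotoxicity, with a stated time of 3 days (on this read-out higher numbers stand for lower toxicity in this test and lower numbers for higher toxicity in this test), compound 1 returns only a limit, > 200000 nM. Compound 2 `CCC1(Cc2ccccc2)OS(=O)(=O)C=C1OCc1ccc([N+](=O)[O-])cc1` has 4-nitrophenyl in that place; in this assay compound 2 likewise gives only a limit, < 200000 nM. Compound 3 `CCC1(Cc2ccccc2)OS(=O)(=O)C=C1OC` has hydrogen there; in this assay compound 3 also gives a limit, > 200000 nM, so its standing rests on a limit alone, as do the two other values shown. The measured steps read a number no higher from compound 1 to compound 2 (the limit leaves the size open), a step that the two limits leave unreadable from compound 1 to compound 3 and a number no lower from compound 2 to compound 3 (the limit leaves the size open); with the limit of < 200000 nM in this assay, at which 1 of the 3 values shown sits, and (the limit of > 200000 nM in this assay, at which 2 of the 3 values shown sit), none yields a readable size. Compound 4 `CCC1(Cc2ccccc2)OS(=O)(=O)C=C1OCc1ccc(Br)cc1` differs from compound 3 by 4-bromophenyl in place of hydrogen on a saturated chain carbon bound to an oxygen on an unsaturated carbon. The step from compound 2 to compound 3, hydrogen in place of 4-nitrophenyl, is the one that bears on it, and its size stayed unreadable. Compound 4 is therefore expected to sit near the limit in this assay, with an estimated downward step of an at least 1.3-fold lower number from compound 3 to compound 4 (0.12 log units; that floor lies within the scatter). The estimate for compound 4 is 150000 nM, between 50000 nM and 300000 nM.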

Compound 4, half-maximal cytotoxic concentration: 171000 nM
The estimate for compound 4 lay 1.1-fold (0.06 log units) below the measured number, within the range that was stated.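

Among the compounds shown here, compound 4 gives the only true number so far in this assay, which shows that a 4-bromophenyl at this place yields a readable value and not just a limit. Set against hydrogen, the change reads an at least 1.1-fold lower number from compound 3 to compound 4 (0.06 log units; that floor lies within the scatter), and set against methoxycarbonyl it reads an at least 1.1-fold lower number from compound 1 to compound 4 (0.06 log units; that floor lies within the scatter); both are floors, so the real size of each step stays open. The step for bromo in place of nitro on an aromatic carbon cannot be read, nor can the older steps in the series: the limit of < 200000 nM in this assay, at which 1 of the 4 values shown sits.

From the compounds shown here alone, whether the ring itself or its bromo group goes with the readable number remains open, and plain phenyl in the same place would bear on that. Going by these compounds, how a 4-aminophenyl, a carboxylic acid or a longer chain would read at this place also remains open.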